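Trifluoromethyl in place of methoxy: what compound 4 may give

A few compounds are considered here, and "the series" means these few. Any claim that something is new, unique, unknown or untested is made for them only; others in the source may bear on it.

Of the compounds shown here, three sharing one core have been measured in a functional assay on A-431 cells (Homo sapiens) for antiproliferative activity, read by MTT assay, with a stated time of 72 h; on this read-out lower numbers stand for stronger inhibition and higher numbers for weaker inhibition. Compound 1 `COc1cc2ncnc(Nc3ccc(Br)cc3)c2cc1OCCCCC(=O)Nc1ccc(S(N)(=O)=O)cc1` gives 6570 nM. Compound 2 `COc1ccc(Nc2ncnc3cc(OC)c(OCCCCC(=O)Nc4ccc(S(N)(=O)=O)cc4)cc23)cc1` gives 14700 nM, the highest of the three numbers, and compound 3 `COc1cc2ncnc(Nc3cccc(C)c3)c2cc1OCCCCC(=O)Nc1ccc(S(N)(=O)=O)cc1` gives 7460 nM. Against compound 2 the others stand as follows: a 2.2-fold higher number from compound 1 to compound 2 (0.35 log units; beyond the scatter), whereas a 2.0-fold lower number from compound 2 to compound 3 (0.29 log units; within the scatter), and between compound 1 and compound 3 the gap is a 1.1-fold higher number from compound 1 to compound 3 (0.06 log units; within the scatter).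

Compound 4 `COc1cc2ncnc(Nc3ccc(C(F)(F)F)cc3)c2cc1OCCCCC(=O)Nc1ccc(S(N)(=O)=O)cc1` is not yet measured. It differs from compound 2 by trifluoromethyl in place of methoxy on an aromatic carbon. The step that bears most directly on it is a 2.2-fold higher number from compound 1 to compound 2 (0.35 log units; beyond the scatter), since that change also swapped one substituent for another at the same place; read backwards, replacing methoxy there by a different group brought a modestly lower number. Compound 3 shows that a third substituent pattern likewise sits near compound 1.

Compound 4 is therefore expected to move in the same direction as compound 1 relative to compound 2, with a 2.1-fold lower number from compound 2 to compound 4 (0.32 log units; beyond the scatter), and its estimated value in this assay is 7000 nM, with a range from 3000 nM to 16000 nM.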

Compound 4, half-maximal inhibitory concentration: 16900 nM
Beside the measured number, compound 4's estimate is 2.4-fold (0.38 log units) below it, and the stated range ends below it.
By their numbers in this assay, from the lowest: compounds 1, 3, 2 and 4 (each within the scatter of the next, the first and the last beyond it).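

There is a 1.1-fold higher number from compound 2 to compound 4 (0.06 log units; within the scatter) in this assay when trifluoromethyl replaces methoxy on the aromatic carbon para to a large group, so these two groups cannot be told apart at this place. Bromo at the same place does stand apart, with a 2.6-fold higher number from compound 1 to compound 4 (0.41 log units; beyond the scatter) when trifluoromethyl replaces it, so the lower number goes with bromo specifically and not with any group other than methoxy. The change from 3-methylphenyl to 4-(trifluoromethyl)phenyl also gives a 2.3-fold higher number from compound 3 to compound 4 (0.36 log units; beyond the scatter) as a modest step, although compound 3 lies within the scatter of compound 2, so compound 2 cannot be placed firmly with either side of the small set.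

Nothing among the data shown accounts for these differences. On these data alone, it remains open whether a nitrile, an amine or a carboxylic acid at this place would side with bromo or with methoxy and trifluoromethyl, and whether the same gaps would hold with a longer chain on the ether oxygen of the shared core.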